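The source may report more compounds than this note shows. Statements on the series, on what has been measured and on what is new or still open speak of the compounds shown alone.

Measured compounds:
- compound 1, `O=c1cc(/C=N\c2ccccc2O)c2c(OCc3ccccc3)cc(OCc3ccccc3)cc2o1`, 7760 nM in a functional assay, read by spectrophotometry, with a stated time of 3 min; on this read-out higher numbers stand for weaker inhibition and lower numbers for stronger inhibition
- compound 2, `O=c1cc(/C=N\Nc2ccc([N+](=O)[O-])cc2)c2ccc(OCc3ccccc3)cc2o1`, 9510 nM in this assay
- compound 3, `O=c1cc(/C=N\Nc2ccc([N+](=O)[O-])cc2[N+](=O)[O-])c2ccc(OCc3ccccc3)cc2o1`, 6490 nM in this assay

Compound 3 gives the smallest number of the three in this assay, but neither other compound is separated from it by more than the scatter: the change a 1.5-fold lower number from compound 2 to compound 3 (0.17 log units; within the scatter) is within the scatter, and compound 1 sits even closer to compound 3.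

Compound 4, `O=c1cc(/C=N\Nc2ccc([N+](=O)[O-])cc2[N+](=O)[O-])c2c(OCc3ccccc3)cc(OCc3ccccc3)cc2o1`, differs from compound 3 as follows: benzyloxy in place of hydrogen on an aromatic carbon. Going by the values given here, no measured step covers this change on its own. Compound 1 carries the same pair of benzyloxy groups as compound 4 but a different partner on the imine, so it is not a clean comparison; its value and that of compound 3 are, in any case, within the scatter of each other. Nothing in the measured steps points to a shift beyond the scatter in this assay for compound 4, so the expected step of a 1.0-fold higher number from compound 3 to compound 4 (0.00 log units; within the scatter) is taken as essentially flat. Compound 4 is therefore estimated at 6500 nM, with a range of 3000 nM to 14000 nM.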

Compound 4, half-maximal inhibitory concentration: "not active" (no number reported)
No number was reported for compound 4, and the estimate cannot be compared.
By their numbers in this assay, from the lowest: compounds 3, 1 and 2 (each within the scatter of the next).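

Going by these compounds alone, compound 4 is recorded as "not active" in this assay with no number, so no step from compound 3 to compound 4 can be read. Nothing shown accounts for this result. The compounds shown leave open what benzyloxy in place of hydrogen does on its own.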